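The source may report more compounds than this note shows. Statements on the series, on what has been measured and on what is new or still open speak of the compounds shown alone.

Among the compounds with values here, in an ADME assay on microsomes from liver (Mus musculus) for metabolic stability, read by LC-MS, using NADPH, with a stated time of 60 min, tested at 1 uM (a higher number here means that the compound lasts longer, a lower number that the compound disappears faster), compound 1 (`O=C(O)CC1Cc2ccc(-c3cc(F)cc(OC(F)F)c3)cc2N1S(=O)(=O)c1cccc(C(F)(F)F)c1`) gives 1.88 h and holds the higher of the two numbers so far, while compound 2 (`O=C(O)CC1CN(S(=O)(=O)c2cccc(C(F)(F)F)c2)c2cc(-c3cc(F)cc(OC(F)F)c3)ccc21`) gives 0.76 h, a gap beyond the usual scatter. Compound 3 (`O=C(CC1Cc2ccc(-c3cc(F)cc(OC(F)F)c3)cc2N1S(=O)(=O)c1cccc(C(F)(F)F)c1)N1CC2(COC2)C1`) keeps the core of compound 1 and differs only in what sits on a carbonyl carbon (a group of 7 heavy atoms (5 carbon, 1 nitrogen, 1 oxygen; 2 four-membered non-aromatic rings with 1 hetero atom each) in place of one oxygen atom, on a carbonyl carbon). Within the data shown here, no measured step shows what such a swap does, so this is a judgment call: a moderate fall is expected, with an estimated 2.4-fold lower number from compound 1 to compound 3 (0.37 log units; beyond the scatter) that probably lies beyond the scatter. Compound 3 is estimated at 0.8 h, with an expected range from 0.3 h to 1.9 h.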

Compound 3, half-life: 0.0117 h
Beside the measured number, compound 3's estimate is 68-fold (1.83 log units) above it; measured number outside the range, below it.
By their numbers in this assay, from the lowest: compound 3; then compound 2; then compound 1.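

This place on the carbonyl carbon turns out to matter greatly in this assay: putting the group of 7 heavy atoms, with its 2 four-membered non-aromatic rings, in place of the hydroxy causes a steep fall (a 160-fold lower number from compound 1 to compound 3 (2.21 log units; beyond the scatter)). The core of compound 1 stays the same, so the whole loss goes with this single change. Nothing at hand explains why the compound disappears so much faster.

Going by these compounds, it remains open whether any group on this carbonyl carbon brings such a loss or only this one, which a methyl ester or a small amine such as dimethylamine in that place could help to tell. On these data alone, it is also open whether the same change on compound 2 would cost as much.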